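Lengthening the tetrazolyl chain: compound 2 to compound 3

The source may report more compounds than this note shows. Statements on the series, on what has been measured and on what is new or still open speak of the compounds shown alone.

Measured so far in a functional assay (ileum) with Cavia porcellus as the target; on this read-out lower numbers stand for stronger inhibition and higher numbers for weaker inhibition:
Compound 1 `CCCc1c(OCCCCCCCC(=O)O)ccc(C(C)=O)c1O`: 794 nM
Compound 2 `CCCc1c(OCCCCCCCCCc2nn[nH]n2)ccc(C(C)=O)c1O`: 251 nM

Compound 2 stands lower of the two at 251 nM on these numbers. Compound 3 `CCCc1c(OCCCCCCCCCCc2nn[nH]n2)ccc(C(C)=O)c1O` differs from it in one place: (2H-tetrazol-5-yl)methyl in place of 2H-tetrazol-5-yl on a saturated chain carbon, nine bonds along the chain from an oxygen on an aromatic ring. Within the data shown here, the only measured step, a 3.2-fold lower number from compound 1 to compound 2 (0.50 log units; beyond the scatter), is modest and swaps carboxy for 2-(2H-tetrazol-5-yl)ethyl, so it says little about a change that keeps the tetrazolyl group. In this assay no shift beyond the scatter is expected, and the expected step is a 1.0-fold lower number from compound 2 to compound 3 (0.00 log units; within the scatter) in size. Compound 3 is estimated at 250 nM with an expected range from 100 nM to 630 nM for now.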

Compound 3, half-maximal inhibitory concentration: 3160 nM
Estimate against measurement, compound 3: 13-fold (1.10 log units) below; the measured number lies above the stated range.
By their numbers in this assay, from the lowest: compound 2; then compound 1; then compound 3.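

In this assay, this chain position proves sensitive to length: (2H-tetrazol-5-yl)methyl in place of 2H-tetrazol-5-yl gives a 13-fold higher number from compound 2 to compound 3 (1.10 log units; beyond the scatter). The tetrazolyl group therefore does not by itself secure the lower number of compound 2, and the longer chain also loses out to the carboxy compound, with a 4.0-fold higher number from compound 1 to compound 3 (0.60 log units; beyond the scatter). No measurement shown here accounts for this loss.

Still open, going by these compounds, is whether a shorter tetrazolyl chain matches compound 2 or improves on it, and whether a still longer chain rises further. Also open, on these data alone, is how a sulfonic acid in place of 2H-tetrazol-5-yl would read.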